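The compounds below may be only part of what the source reports. "The series", "measured", "known", "first", "only" and "open" are said of these compounds alone.

Of the compounds shown here, three sharing one core have been measured in a functional assay on A549 cells (Homo sapiens) for cytotoxicity, read by MTT assay, with a stated time of 72 h; a higher number here means a weaker inhibitor, a lower number a stronger inhibitor. Compound 1 `O=C1c2c[n+]([O-])c3ccccc3c2C(=O)c2c1c1ccccc1n2Cc1cn(C[C@H](O)CO)nn1` gives 1030 nM, and compound 2 `O=C1c2c[n+]([O-])c3ccccc3c2C(=O)c2c1c1ccccc1n2Cc1cn(CC(O)CO)nn1`, the same structure with its stereocentre drawn without a configuration, gives 880 nM. That is a 1.2-fold lower number from compound 1 to compound 2 (0.07 log units; within the scatter). Compound 3 `CN1CCN(CCCCn2c3c(c4ccccc42)C(=O)c2c[n+]([O-])c4ccccc4c2C3=O)CC1` has the lowest number of the three, at 90 nM. Putting 3-(4-methylpiperazin-1-yl)propyl in place of 1-(2,3-dihydroxypropyl)-1H-1,2,3-triazol-4-yl gave an 11-fold lower number from compound 1 to compound 3 (1.06 log units; beyond the scatter) and a 9.8-fold lower number from compound 2 to compound 3 (0.99 log units; beyond the scatter).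

Compound 4 `CCCCN1CCN(CCCCn2c3c(c4ccccc42)C(=O)c2c[n+]([O-])c4ccccc4c2C3=O)CC1` differs from compound 3 by propyl in place of hydrogen on a saturated chain carbon bound to an amine nitrogen in a ring, which turns 4-methylpiperazin-1-yl into 4-butylpiperazin-1-yl. Within the data shown here, both large steps exchanged a whole side chain, so they are only a loose guide to this smaller edit, and no measured pair isolates it. The best anchor is therefore compound 3 at 90 nM, and no firm shift is expected, although a slightly higher number is allowed for. The expected change is a 1.3-fold higher number from compound 3 to compound 4 (0.12 log units; within the scatter). For compound 4 the estimated value is 120 nM, with an expected range from 40 nM to 350 nM.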

Compound 4, half-maximal inhibitory concentration: 550 nM
Estimate against measurement, compound 4: 4.6-fold (0.66 log units) below, and the stated range ends below it.
By their numbers in this assay, from the lowest: compound 3; then compounds 4, 2 and 1 (each within the scatter of the next).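

In this assay, the far end of the side chain proves sensitive: turning 4-methylpiperazin-1-yl into 4-butylpiperazin-1-yl gives a 6.1-fold higher number from compound 3 to compound 4 (0.79 log units; beyond the scatter), although the rest of the molecule stays the same. The earlier large steps exchanged a whole side chain, so they could not show that adding propyl in place of hydrogen at this one place is enough to move the number beyond the scatter. Nothing in the evidence available bears on what lies behind this loss of activity.

With only methyl and butyl shown at this place, it remains open whether the number rises steadily with chain length or jumps at one particular size, which ethyl or propyl in place of the methyl would help to settle. On these data alone, how a hydrogen or a 2-hydroxyethyl group would behave there also remains unknown.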